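A few compounds are considered here, and "the series" means these few. Any claim that something is new, unique, unknown or untested is made for them only; others in the source may bear on it.

In a functional assay on MCF7 cells (Homo sapiens) for antiproliferative activity, read by CCK-8 assay, with a stated time of 48 h (on this read-out lower numbers stand for stronger inhibition and higher numbers for weaker inhibition), three compounds with a shared core have been measured: compound 1 `Cc1cc(Nc2cc(N3CCN(C)CC3)nc(Nc3ccc(Cl)c(F)c3)n2)n[nH]1` gives 818 nM, compound 2 `Cc1cc(Nc2cc(N3CCN(C)CC3)nc(Nc3ccc(F)c(Cl)c3)n2)n[nH]1` gives 213 nM, and compound 3 `Cc1cc(Nc2cc(N3CCN(C)CC3)nc(Nc3ccc(Cl)c(Cl)c3)n2)n[nH]1` gives 552 nM. Compound 3 cannot be told apart from compound 1, but its number is clearly higher than that of compound 2, with a 2.6-fold higher number from compound 2 to compound 3 (0.41 log units; beyond the scatter).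

Compound 4 `Cc1cc(Nc2cc(N3CCN(C)CC3)nc(Nc3ccc(F)c(F)c3)n2)n[nH]1` is still unmeasured. It has 3,4-difluorophenyl in place of 3,4-dichlorophenyl on a nitrogen on an aromatic ring. Compound 1 and compound 2 each carry one chloro and one fluoro, so they show what a single exchange does. Going by the values given here, two measured steps bear on this, each with chloro in place of fluoro: a 1.5-fold lower number from compound 1 to compound 3 (0.17 log units; within the scatter) and a 2.6-fold higher number from compound 2 to compound 3 (0.41 log units; beyond the scatter). Read backwards, one fluoro exchange made no clear difference and the other lowered the number modestly. The two compounds also differ from each other, with a 3.8-fold lower number from compound 1 to compound 2 (0.58 log units; beyond the scatter), so the outcome depends on which chloro is exchanged.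

Combining both exchanges, the expected change is a 1.7-fold lower number from compound 3 to compound 4 (0.24 log units; within the scatter), a lower number but probably not clearly beyond the scatter. Compound 4 is estimated at 320 nM, within an expected range of 120 nM to 800 nM.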

Compound 4, half-maximal inhibitory concentration: 1290 nM
Beside the measured number, compound 4's estimate is 4.0-fold (0.61 log units) below it, and the stated range ends below it.
By their numbers in this assay, from the lowest: compound 2; then compounds 3, 1 and 4 (each within the scatter of the next, the first and the last beyond it).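

In this assay, exchanging both chloro groups for fluoro gives a 2.3-fold higher number from compound 3 to compound 4 (0.37 log units; beyond the scatter), so the two exchanges together raise the number, although one of them alone, read from compound 3 to compound 2, lowers it. Which chloro stays matters: with the 3-chloro-4-fluorophenyl group of compound 2 as the starting point, the exchange gives a 6.1-fold higher number from compound 2 to compound 4 (0.78 log units; beyond the scatter), whereas with the 4-chloro-3-fluorophenyl group of compound 1 it gives a 1.6-fold higher number from compound 1 to compound 4 (0.20 log units; within the scatter). The exchange of fluoro and chloro therefore has no fixed size on this ring, and its size depends on the place and on the other halogen present: the same change on two cores in this assay, a 1.5-fold lower number (0.17 log units; within the scatter) from compound 1 to compound 3 and a 6.1-fold lower number (0.78 log units; beyond the scatter) from compound 4 to compound 2, 4.1-fold (0.61 log units) apart, beyond the scatter of two such steps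

The compounds shown leave open what an unsubstituted phenyl would give on this nitrogen, and so what the halogens contribute at all. They also leave open whether a methyl, methoxy or nitrile in place of either halogen would keep the number of compound 2.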